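The compounds below may be only part of what the source reports. "The series", "measured", "known", "first", "only" and "open" are said of these compounds alone.

Of the compounds shown here, three from one series have been measured in a functional assay on MCF7 cells (Homo sapiens) for cytotoxicity, read by MTT assay, with a stated time of 72 h; on this read-out higher numbers stand for weaker inhibition and lower numbers for stronger inhibition. Compound 1, with the structure `Cn1ccc2c(Oc3ccc(NC(=O)c4nn(-c5ccc(Cl)c(F)c5)ccc4=O)cc3)ccnc21`, gives 16800 nM in this assay. Compound 2, with the structure `Cn1ccc2c(Oc3ccc(NC(=O)c4nn(-c5ccc(Br)cc5F)ccc4=O)cc3F)ccnc21`, gives 14100 nM. Compound 3, with the structure `Cc1cc(=O)n(-c2ccc(F)cc2)nc1C(=O)Nc1ccc(Oc2ncnc3[nH]ccc23)cc1`, gives 4800 nM, the lowest of the three numbers and thus the strongest inhibition recorded here. Its nearest neighbour on the numbers is compound 2, whose value is higher by an amount beyond the usual scatter, and compound 1 sits further away still. Compounds 1 and 2 differ from compound 3 in several places at once, so no single structural change can be read from those gaps.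

Compound 4, with the structure `Cc1ccc(-n2nc(C(=O)Nc3ccc(Oc4ncnc5[nH]ccc45)cc3)c(C)cc2=O)cc1`, has not yet been measured. It differs from compound 3 in one place only: methyl in place of fluoro on an aromatic carbon. Swapping one small group for another on the outer ring of the molecule often leaves the numbers close to where they were, and nothing among the measured compounds argues otherwise. The step from compound 3 to compound 4 is therefore expected to be small, a 1.1-fold higher number from compound 3 to compound 4 (0.06 log units; within the scatter), within or just beyond the scatter. Compound 4 is estimated to give about 5500 nM, with a likely range from 2000 nM to 15000 nM.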

Compound 4, half-maximal inhibitory concentration: 3620 nM
For compound 4 the middle estimate is 1.5-fold (0.18 log units) above the measured one, and the stated range covers the measured number.
By their numbers in this assay, from the lowest: compounds 4 and 3 (each within the scatter of the next); then compounds 2 and 1 (each within the scatter of the next).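

On an aromatic carbon para to a large group, methyl in place of fluoro gives a 1.3-fold lower number from compound 3 to compound 4 (0.12 log units; within the scatter) in this assay. Going by these compounds alone, this is the first comparison in which only one place changes, and it shows that going from 4-fluorophenyl to 4-methylphenyl leaves the number indistinguishable from where it was, something the earlier compounds, which differ in several places at once, could not show. No supporting measurement accompanies this result, so the data give no account of why these two groups read alike.

From the compounds shown here alone, it remains open whether a quite different group at this position, such as an amine, a carboxylic acid or a longer chain, would shift the number beyond the scatter. Also open is whether methyl in place of fluoro would read the same on another core, as this is the only such pair shown.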